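The source may report more compounds than this note shows. Statements on the series, on what has been measured and on what is new or still open speak of the compounds shown alone.

Measured in an assay on CHO cells for displacement of a labelled ligand from adenosine receptor A1 (Homo sapiens), read by scintillation counting, tested at 10 uM; a lower number here means less inhibition, a higher number more inhibition at the concentration tested (going by the name of the read-out):
compound 1 `CC(C)(C)c1csc(N)c1C(=O)c1ccc(Cl)cc1` gives 1%
compound 2 `COc1ccc(-c2sc(N)c(C(=O)c3ccc(Cl)cc3)c2C)cc1` gives 1%
compound 3 `CC(C)(C)Cc1c(-c2ccc(F)cc2F)sc(N)c1C(=O)c1ccc(Cl)cc1` gives 1%

Compound 3 stands level with compound 1 and compound 2 at the digits shown. Its nearest neighbour on the numbers is compound 1, with no change at the digits shown and within the scatter; its furthest is compound 2, again with no change at the digits shown and within the scatter. Among the compounds with values here, all three measured compounds sit at the same reading in this assay, so the set gives no step between measured compounds and no spread of values to lean on.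

Compound 4 `Cc1cccc(-c2sc(N)c(C(=O)c3ccc(Cl)cc3)c2CC(C)(C)C)c1` is the next compound for this assay. The change from compound 3 is 3-methylphenyl in place of 2,4-difluorophenyl on an aromatic carbon. Within the data shown here, no step between measured compounds is available for a change of this kind, and the three measured readings do not separate one another. With every measured compound at the same reading, the expected step of a number 1 percentage points higher from compound 3 to compound 4 (within the scatter) is none beyond the scatter. Compound 4 is estimated at 2% in this assay, with a range from -7% to 12%.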

Compound 4, a percentage reported as inhibition, at one concentration (the size of the read-out at that concentration, not a potency): 1%
Estimate against measurement, compound 4: 1 percentage points above, and the stated range covers the measured number.
By their numbers in this assay, from the lowest: compounds 1, 2, 3 and 4 (each within the scatter of the next).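

In this assay, within the data shown here, the exchange of 2,4-difluorophenyl for 3-methylphenyl on the aromatic carbon next to the ring sulfur gives no change at the digits printed from compound 3 to compound 4 (within the scatter) and so supplies the first step between compounds that differ in one place. With the neopentyl group, the amino group and the (4-chlorophenyl)carbonyl group held constant, a phenyl ring carrying two fluorines and one carrying a methyl group are not told apart at this position. No measurement at hand bears on the reason for this unchanged reading.

Among these compounds, the step covers only this one pair of groups, so it does not show whether any substituent at this position can move the reading in this assay. Going by these compounds, whether an amine or a carboxylic acid on this phenyl ring, or a longer chain in place of the neopentyl group, would lift the reading clear of the scatter remains open.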